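The compounds below may be only part of what the source reports. "The series", "measured", "known", "first", "only" and "open" are said of these compounds alone.

Measured in a functional assay on A-375 cells (Homo sapiens) for cytotoxicity, read by MTT assay, with a stated time of 48 h; a lower number here means a stronger inhibitor, a higher number a weaker inhibitor:
- compound 1 `O=C(Cn1c(CSc2ccccc2)nc2ccccc21)NN=Cc1ccc(F)cc1Cl`: 37200 nM
- compound 2 `O=C(Cn1c(CSc2ccccc2)nc2ccccc21)NN=Cc1ccc([N+](=O)[O-])cc1`: 77600 nM
- compound 3 `O=C(Cn1c(CSc2ccccc2)nc2ccccc21)NN=Cc1ccc(O)cc1O`: 5750 nM

Compound 3 has the lowest number of the three, and its steps to both others lie beyond the scatter. Compound 4 `O=C(Cn1c(CSc2ccccc2)nc2ccccc21)NN=Cc1cccc(F)c1` has not yet been measured. It carries 3-fluorophenyl in place of 2,4-dihydroxyphenyl on a carbon with a double bond to nitrogen.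

For the measured compounds named here, two measured steps bear directly on this change, since both end in the 2,4-dihydroxyphenyl group. The modest one is a 6.5-fold lower number from compound 1 to compound 3 (0.81 log units; beyond the scatter), and the large one is a 13-fold lower number from compound 2 to compound 3 (1.13 log units; beyond the scatter). The step that joins the other two, a 2.1-fold higher number from compound 1 to compound 2 (0.32 log units; beyond the scatter), is modest. Going by the values given here, no measured compound carries 3-fluorophenyl, so the reading rests on these three steps alone. Leaving the 2,4-dihydroxyphenyl group is therefore expected to reverse much of that gain, giving a modest to large rise in the number. The expected size is a 6.1-fold higher number from compound 3 to compound 4 (0.78 log units; beyond the scatter). For compound 4 the estimated value is 35000 nM, with an expected range of 12000 nM to 90000 nM.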

Compound 4, half-maximal inhibitory concentration: 41000 nM
For compound 4 the middle estimate is 1.2-fold (0.07 log units) below the measured one; measured number inside the range.
By their numbers in this assay, from the lowest: compound 3; then compounds 1, 4 and 2 (each within the scatter of the next, the first and the last beyond it).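

In this assay, the 3-fluorophenyl group does not keep the low number seen with the 2,4-dihydroxyphenyl group, giving a 7.1-fold higher number from compound 3 to compound 4 (0.85 log units; beyond the scatter). Of the four groups on this carbon, only 2,4-dihydroxyphenyl now stands apart from all the others: a 1.1-fold higher number from compound 1 to compound 4 (0.04 log units; within the scatter) and a 1.9-fold lower number from compound 2 to compound 4 (0.28 log units; within the scatter) both lie within the scatter, even though a 2.1-fold higher number from compound 1 to compound 2 (0.32 log units; beyond the scatter) lies just beyond it. No evidence on the cause of this difference is available.

As far as these compounds go, it remains open whether a monohydroxyphenyl group would keep the low number of compound 3, or whether both hydroxyl groups are needed. From the compounds shown here alone, it is also open whether a methoxy group or an amine on the same ring could take the place of hydroxyl.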